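A few compounds are considered here, and "the series" means these few. Any claim that something is new, unique, unknown or untested is made for them only; others in the source may bear on it.

Working notes on the sulfur-linked series.

Compound 1 `Cc1cc(Nc2cc(-c3ccccc3)[nH]n2)n2nc(SCCc3ccccc3)nc2n1`, compound 2 `Cc1cc(Nc2cc(-c3ccccc3)[nH]n2)n2nc(SCc3c(Cl)cccc3Cl)nc2n1` and compound 3 `C#CCSc1nc2nc(C)cc(Nc3cc(-c4ccccc4)[nH]n3)n2n1` have been run in a functional assay on MCF7 cells (Homo sapiens) for inhibition, read by MTT assay, with a stated time of 72 h; on this read-out higher numbers stand for weaker inhibition and lower numbers for stronger inhibition. Compound 1 gives 2700 nM, compound 2 gives 3230 nM and compound 3 gives 21800 nM, so compound 1 holds the lowest number of the three, with compound 2 closest and compound 3 furthest. Between the two ring-bearing analogues the step is a 1.2-fold higher number from compound 1 to compound 2 (0.08 log units; within the scatter). Dropping the ring costs more: an 8.1-fold higher number from compound 1 to compound 3 (0.91 log units; beyond the scatter) and a 6.7-fold higher number from compound 2 to compound 3 (0.83 log units; beyond the scatter).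

Compound 4 `Cc1cc(Nc2cc(-c3ccccc3)[nH]n2)n2nc(SCc3cccc4ccccc34)nc2n1` has not been measured. It differs from compound 1 in one place: naphthalen-1-yl in place of benzyl on a saturated chain carbon bound to a sulfur. Going by the values given here, the step from compound 1 to compound 2 bears directly, one ring replacing another on the same carbon, and stayed within the scatter; the steps to compound 3 show only that losing the ring weakens inhibition. On that basis no step beyond the scatter is expected in this assay for compound 4, at most a slight drift to a lower number. Compound 4 is expected at 2400 nM, within 900 nM to 6500 nM. The implied step from compound 1 is estimated as a 1.1-fold lower number from compound 1 to compound 4 (0.05 log units; within the scatter).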

Compound 4, half-maximal inhibitory concentration: 7560 nM
Beside the measured number, compound 4's estimate is 3.2-fold (0.50 log units) below it; measured number above the stated range.
By their numbers in this assay, from the lowest: compounds 1 and 2 (each within the scatter of the next); then compound 4; then compound 3.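

Ring identity at this position, on a saturated chain carbon bound to a sulfur, now matters in this assay: naphthalen-1-yl gives a 2.8-fold higher number from compound 1 to compound 4 (0.45 log units; beyond the scatter) and a 2.3-fold higher number from compound 2 to compound 4 (0.37 log units; beyond the scatter), so the earlier equivalence of compound 1 and compound 2 does not extend to every aromatic group. An aromatic ring still outperforms ethynyl here, with a 2.9-fold lower number from compound 3 to compound 4 (0.46 log units; beyond the scatter), which places compound 4 in an intermediate position rather than at either end of the series. No data available here account for the loss on moving to the larger ring system.

As far as these compounds go, it remains open whether naphthalen-2-yl, a pyridyl ring or a longer chain ending in phenyl would return to the level of compound 1. From the compounds shown here alone, the effect of an amine or a carboxylic acid on this chain also remains open.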